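The compounds below may be only part of what the source reports. "The series", "measured", "known", "first", "only" and "open" are said of these compounds alone.

Three compounds have been measured in a functional assay on MCF7 cells (Homo sapiens) for cytotoxicity, read by MTT assay, with a stated time of 72 h; on this read-out higher numbers stand for weaker inhibition and lower numbers for stronger inhibition:

Compound 1 `Cc1ccc(-n2nc(C(=O)Nc3ccc(Oc4ncnc5ccsc45)cc3)c(C)cc2=O)cc1`: 23800 nM
Compound 2 `Cc1ccc(-n2nc(C(=O)Nc3ccc(Oc4ncnc5ccsc45)cc3)c(C)cc2=O)c(C)c1`: 11900 nM
Compound 3 `O=C(Nc1ccc(Oc2ncnc3ccsc23)c(F)c1)c1nn(-c2ccccc2)ccc1=O`: 12400 nM

Compound 1 and compound 2 differ by methyl in place of hydrogen on an aromatic carbon, and this gave a 2.0-fold lower number from compound 1 to compound 2 (0.30 log units; within the scatter). Compound 3 carries a different core from compound 1; the difference between the two cores is not broken down here. The value of compound 3 lies within the scatter of the values of compound 2 and of compound 1.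

Compound 4 `Cc1ccc(-n2ccc(=O)c(C(=O)Nc3ccc(Oc4ncnc5ccsc45)c(F)c3)n2)cc1` has not yet been measured in this assay. It differs from compound 3 by methyl in place of hydrogen on an aromatic carbon. This is the same kind of change as that from compound 1 to compound 2, though its surroundings differ: in compound 2 the new methyl sits ortho to a large group and meta to a methyl group, whereas in compound 4 it sits para to a large group. Resting on a 2.0-fold lower number from compound 1 to compound 2 (0.30 log units; within the scatter), the step from compound 3 to compound 4 in this assay is expected to be small, a 1.5-fold lower number from compound 3 to compound 4 (0.16 log units; within the scatter). Compound 4 is therefore estimated at 8500 nM, expected to fall between 3500 nM and 21000 nM.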

Compound 4, half-maximal inhibitory concentration: 23200 nM
The estimate for compound 4 lay 2.7-fold (0.44 log units) below the measured number; measured number outside the range, above it.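

In this assay, the change from phenyl to 4-methylphenyl gave a 1.9-fold higher number from compound 3 to compound 4 (0.27 log units; within the scatter). Set beside the earlier step, the same change did not carry over from one core to the other: the same change on two cores in this assay, a 2.0-fold lower number (0.30 log units; within the scatter) from compound 1 to compound 2 and a 1.9-fold higher number (0.27 log units; within the scatter) from compound 3 to compound 4, 3.7-fold (0.57 log units) apart, beyond the scatter of two such steps. This shows that, in this series, a step read on one core cannot simply be transferred to another; it does not show what lies behind the gap, for each step taken alone stays within the scatter, the methyl sits at a different place in the two pairs, the cores differ in more than one place, and two pairs give no rule for any further core.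

The compounds shown leave open whether a chlorine, a methoxy group, an amine or a carboxylic acid at the place of this methyl would also give steps that differ between the two cores. They also leave open whether a longer chain there would follow the step on one core or on the other.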